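The source may hold more compounds than are shown below. What is called first, only, known or untested is meant among the compounds shown, and "the series" means these compounds.

Measured compounds:
- compound 1, `COc1cccc(-c2c(C)n(Cc3c(F)cccc3F)c(=O)n(C[C@H](N)CC(C)C)c2=O)c1F`: 6.4 nM in an assay on HEK293 cells for binding affinity to Gonadotropin-releasing hormone receptor (Homo sapiens), read by radioligand binding; on this read-out higher numbers stand for weaker inhibition and lower numbers for stronger inhibition
- compound 2, `CN[C@H](CC(C)C)Cn1c(=O)c(-c2cccc(OC)c2F)c(C)n(Cc2c(F)cccc2F)c1=O`: 1.2 nM
- compound 3, `COc1cccc(-c2c(C)n(Cc3c(F)cccc3F)c(=O)n(C[C@@H](N)C3CCCCC3)c2=O)c1F`: 46 nM

Compound 3 gives the highest number of the three in this assay: compound 1 sits closer to it, compound 2 furthest. The step of a 7.2-fold higher number from compound 1 to compound 3 (0.86 log units; beyond the scatter) and the step of a 38-fold higher number from compound 2 to compound 3 (1.58 log units; beyond the scatter) both run toward weaker binding on going to the cyclohexyl compound; the step of a 5.3-fold lower number from compound 1 to compound 2 (0.73 log units; beyond the scatter) concerns the amine nitrogen and does not touch the chain substituent.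

Compound 4, `COc1cccc(-c2c(C)n(Cc3c(F)cccc3F)c(=O)n(C[C@@H](N)CC(C)C)c2=O)c1F`, has not been measured. It differs from compound 3 by isobutyl in place of cyclohexyl on a saturated chain carbon bound to an amine nitrogen and a saturated chain carbon. For the measured compounds named here, only one measured step bears directly on this change, and it is the reverse of a 7.2-fold higher number from compound 1 to compound 3 (0.86 log units; beyond the scatter), a modest step. Compound 4 and compound 1 share the same connectivity but differ in the arrangement at the amine-bearing carbon, so the reversal may not transfer exactly. Compound 4 is therefore expected to give a modest step toward lower numbers, a 5.8-fold lower number from compound 3 to compound 4 (0.76 log units; beyond the scatter), with an estimated value of 8 nM (range 2 nM to 40 nM).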

Compound 4, inhibition constant: 39 nM
Estimate against measurement, compound 4: 4.9-fold (0.69 log units) below; measured number inside the range.
By their numbers in this assay, from the lowest: compound 2; then compound 1; then compounds 4 and 3 (each within the scatter of the next).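

In this assay, the change from cyclohexyl to isobutyl on this chain carbon gives a 1.2-fold lower number from compound 3 to compound 4 (0.07 log units; within the scatter), so with the arrangement shared by these two as drawn, the two groups cannot be told apart. The larger gap lies instead in a 6.1-fold higher number from compound 1 to compound 4 (0.78 log units; beyond the scatter), which shows that the arrangement at the amine-bearing carbon matters here and that the earlier step from compound 1 to compound 3 cannot be read as a change of chain group alone: the fact that compounds 1 and 4 differ only in the configuration as drawn The step of a 33-fold higher number from compound 2 to compound 4 (1.51 log units; beyond the scatter) is large, but it combines methyl on the amine nitrogen with the inverted arrangement and isolates neither.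

On these data alone, whether methyl on the amine nitrogen gives a similar step in the arrangement of compound 4 remains open, as does how cyclohexyl behaves in the arrangement of compound 1. A phenyl group or a longer chain on this carbon also remains unplaced in either arrangement.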